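This account rests on a few compounds, and the source may have more. Where it says the series, first, only, none or still open, it means among the compounds named here.

Three compounds share one core and differ only in the group attached to a nitrogen on the aromatic ring. Compound 1 `C=CC(=O)Nc1cccc(NC(=O)CSc2nc(Nc3ccccc3F)c3ccccc3n2)c1` carries a fluorine there, compound 2 `C=CC(=O)Nc1cccc(NC(=O)CSc2nc(Nc3ccccc3Cl)c3ccccc3n2)c1` a chlorine, and compound 3 `C=CC(=O)Nc1cccc(NC(=O)CSc2nc(Nc3ccccc3C)c3ccccc3n2)c1` a methyl. In a functional assay on MGC-803 cells (Homo sapiens) for inhibition, read by MTT assay, with a stated time of 72 h (on this read-out higher numbers stand for weaker inhibition and lower numbers for stronger inhibition), compound 1 gives 26100 nM, compound 2 gives 20700 nM, and compound 3 gives 30200 nM. Compound 3 has the highest of the three numbers, but none of them is separated from another: there was a 1.3-fold lower number from compound 1 to compound 2 (0.10 log units; within the scatter), a 1.2-fold higher number from compound 1 to compound 3 (0.06 log units; within the scatter) and a 1.5-fold higher number from compound 2 to compound 3 (0.16 log units; within the scatter), so the three cannot be ordered.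

Compound 4 `C=CC(=O)Nc1cccc(NC(=O)CSc2nc(Nc3cccc(F)c3)c3ccccc3n2)c1` changes the group in a different way: 3-fluorophenyl in place of 2-methylphenyl on a nitrogen on an aromatic ring. For the measured compounds named here, no measured pair covers a move of the substituent to another place on that phenyl ring; the three measured swaps, all at the same place and all within the scatter, bear on it only indirectly. They suggest that this assay is not sensitive to the group on this nitrogen. For compound 4 the expected step is therefore a 1.1-fold lower number from compound 3 to compound 4 (0.05 log units; within the scatter), none beyond the scatter. Compound 4 is expected to give about 27000 nM in this assay, in a range from 12000 nM to 60000 nM.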

Compound 4, half-maximal inhibitory concentration: 6250 nM
Compound 4: the middle estimate sits 4.3-fold (0.64 log units) above what was measured; measured number below the stated range.
By their numbers in this assay, from the lowest: compound 4; then compounds 2, 1 and 3 (each within the scatter of the next).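

In this assay the group on this nitrogen turns out to matter: there is a 4.8-fold lower number from compound 3 to compound 4 (0.68 log units; beyond the scatter) and a 3.3-fold lower number from compound 2 to compound 4 (0.52 log units; beyond the scatter), both modest but beyond the scatter. The closest comparison is a 4.2-fold lower number from compound 1 to compound 4 (0.62 log units; beyond the scatter), where 2-fluorophenyl and 3-fluorophenyl carry the same atoms and differ only in where the fluorine sits, so the phenyl ring responds to a move of its substituent, although swapping fluoro, chloro and methyl at one place gave no separable change. Nothing available explains this step.

On these data alone, with only one fluorine moved, it remains open whether the lower number belongs to that new place on the ring or to fluorine itself. A chlorine or a methyl in place of the fluorine of 3-fluorophenyl, or a plain phenyl ring, would help separate these two readings.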